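A few compounds are considered here, and "the series" means these few. Any claim that something is new, unique, unknown or untested is made for them only; others in the source may bear on it.

Compound 1 `O=C(Nc1cccc(-n2cc(-c3ccncc3)c(-c3cc(O)cc(Cl)c3)n2)c1)Nc1ccc(Cl)c(C(F)(F)F)c1` gives 97% in a functional assay on HCC 2998 cells (Homo sapiens) for inhibition, read by sulforhodamine B assay, with a stated time of 48 h, tested at 0.1 uM; a higher number here means a weaker effect of the compound at the concentration tested, a lower number a stronger effect. Compound 2 `O=C(Nc1cccc(-n2cc(-c3ccncc3)c(-c3cc(O)cc(Cl)c3)n2)c1)Nc1ccc(Cl)c(Cl)c1` gives 110%. Compound 3 `COc1cc(Cl)cc(-c2nn(-c3cccc(NC(=O)Nc4cc(C(F)(F)F)cc(C(F)(F)F)c4)c3)cc2-c2ccncc2)c1` gives 105%.

All three numbers sit close to one another. Compound 3 stands second highest of the three; its nearest neighbour is compound 2, and its furthest is compound 1, and both gaps lie within the scatter, so compound 3 is not separated from either of them in this assay.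

Compound 4 `COc1cc(Cl)cc(-c2nn(-c3cccc(NC(=O)Nc4cccc(C(F)(F)F)c4)c3)cc2-c2ccncc2)c1` has yet to be measured. It differs from compound 3 in one place: hydrogen in place of trifluoromethyl on an aromatic carbon. Among the compounds with values here, the only measured step that touches a comparable position is a number 13 percentage points higher from compound 1 to compound 2 (beyond the scatter), a modest step beyond the scatter, and that step put chloro rather than hydrogen in place of trifluoromethyl. Nothing measured removes a trifluoromethyl group outright, so the guidance is indirect. Within the data shown here, with every number so far lying close together, the expected change is a number 2 percentage points lower from compound 3 to compound 4 (within the scatter), that is, none beyond the scatter. Compound 4 is therefore estimated at 103%, within a range of 90% to 116%.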

Compound 4, a percentage reported as activity, at one concentration (the size of the read-out at that concentration, not a potency): 98%
Compound 4: the middle estimate sits 5 percentage points above what was measured; measured number inside the range.
By their numbers in this assay, from the lowest: compounds 1, 4, 3 and 2 (each within the scatter of the next, the first and the last beyond it).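

Within the data shown here, this is the first measured case in which a trifluoromethyl group leaves outright, with nothing but hydrogen in its place, and in this assay the change gives a number 7 percentage points lower from compound 3 to compound 4 (within the scatter). At this aromatic carbon, meta to a trifluoromethyl group, the change therefore leaves the read-out at the tested concentration with no separable shift, so the second trifluoromethyl group of compound 3 is not shown to matter here. No independent measurement bears on this result.

On these data alone, whether a different group at this carbon, such as an amine, a nitrile or a carboxylic acid, would move the number beyond the scatter remains open. So does the effect of removing the remaining trifluoromethyl group, and no pair here isolates the hydroxyl-to-methoxy change on the shared core.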